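This account rests on a few compounds, and the source may have more. Where it says the series, first, only, none or still open, it means among the compounds named here.

Compound 1 `N#Cc1ccc(Nc2nccc(OCc3cccnc3)n2)cc1` gives 6400 nM in an ADME assay on MT4 cells (Homo sapiens) for cytotoxicity, read by MTT assay, with a stated time of 5 days; on this read-out higher numbers stand for lower toxicity in this test and lower numbers for higher toxicity in this test
Compound 2 `N#Cc1ccc(Nc2nccc(OCc3ccc(Cl)cc3)n2)cc1` gives 156000 nM
Compound 3 `N#Cc1ccc(Nc2nccc(OCc3ccccc3Br)n2)cc1` gives 130000 nM
Compound 4 `N#Cc1ccc(Nc2nccc(OCc3ccc(Br)cc3)n2)cc1` has not yet been measured

Compound 3 sits in the high group of this small set. Its nearest neighbour shows a 1.2-fold lower number from compound 2 to compound 3 (0.08 log units; within the scatter), while its furthest shows a 20-fold higher number from compound 1 to compound 3 (1.31 log units; beyond the scatter).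

The next change keeps the same atoms but joins them differently: 4-bromophenyl in place of 2-bromophenyl on a saturated chain carbon bound to an oxygen on an aromatic ring. In words, it is 4-bromophenyl in place of 2-bromophenyl on a saturated chain carbon bound to an oxygen on an aromatic ring.

Among the compounds with values here, no measured pair isolates this change, so the closest evidence is indirect. Swapping 4-chlorophenyl for 2-bromophenyl gave a 1.2-fold lower number from compound 2 to compound 3 (0.08 log units; within the scatter) in this assay, a step inside the scatter. The large steps, a 24-fold higher number from compound 1 to compound 2 (1.39 log units; beyond the scatter) and a 20-fold higher number from compound 1 to compound 3 (1.31 log units; beyond the scatter), both came from removing pyridin-3-yl. Compound 4 involves no such swap, as both groups in this change have one six-membered aromatic ring of carbon only. A step beyond the scatter is therefore not expected, and compound 4 should stay in the high group with compound 2 and compound 3.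

The expected outcome is a 1.1-fold higher number from compound 3 to compound 4 (0.03 log units; within the scatter), which would be no real change.

For compound 4 the estimated value is 140000 nM, with an expected range from 60000 nM to 300000 nM.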

Compound 4, half-maximal cytotoxic concentration: 16000 nM
Estimate against measurement, compound 4: 8.8-fold (0.94 log units) above; the whole stated range lies above it.
By their numbers in this assay, from the lowest: compound 1; then compound 4; then compounds 3 and 2 (each within the scatter of the next).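

Within the high group, the place of the bromine on the ring turns out to matter: in this assay, 4-bromophenyl in place of 2-bromophenyl, with the same atoms joined differently, gives an 8.1-fold lower number from compound 3 to compound 4 (0.91 log units; beyond the scatter), which here means higher toxicity in this test. The halogen on that ring matters as well, since bromo in place of chloro on an aromatic carbon gives a 9.8-fold lower number from compound 2 to compound 4 (0.99 log units; beyond the scatter), so a ring of carbon only with a halogen on it does not by itself ensure a number as high as those of the 2-bromophenyl and 4-chlorophenyl compounds. Compared with the pyridin-3-yl compound, the 4-bromophenyl group still gives a 2.5-fold higher number from compound 1 to compound 4 (0.40 log units; beyond the scatter), which places the new compound between the earlier extremes rather than in the high group.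

Nothing available explains why such a small rearrangement shifts the number this far. Still open, as far as these compounds go, is how the number would respond to a fluoro, iodo or methoxy group on the phenyl ring, or to a longer chain joining that ring to the oxygen.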